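This account rests on a few compounds, and the source may have more. Where it says the series, first, only, none or still open, it means among the compounds named here.

Compound 1 `COc1cc(/C=C2\CN(C)C/C(=C\c3cccnc3)C2=O)cc(OC)c1` gives 17900 nM
Compound 2 `CN1C/C(=C\c2cccnc2)C(=O)/C(=C/c2cc([N+](=O)[O-])ccc2F)C1` gives 6170 nM
Compound 3 `Cc1ccc(S(=O)(=O)N2C/C(=C\c3cccnc3)C(=O)/C(=C/c3ccccc3F)C2)cc1` gives 10300 nM

For the measured compounds named here, all three values come from a functional assay on SMMC-7721 cells (Homo sapiens) for cytotoxicity, read by MTT assay, with a stated time of 24 h (a higher number here means a weaker inhibitor, a lower number a stronger inhibitor), and no measured pair differs in one place only. Compound 3 at 10300 nM lies within the scatter of both compound 1 and compound 2.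

Compound 4 `O=C1/C(=C/c2cccnc2)CN(S(=O)(=O)c2ccc(Cl)cc2)C/C1=C\c1ccccc1F` differs from compound 3 in one place (chloro in place of methyl on an aromatic carbon) with chloro in place of methyl on an aromatic carbon, para to a large group. Going by the values given here, no measured pair shows this change, so the expectation rests on compound 3 at 10300 nM alone. The expected step is a 1.1-fold lower number from compound 3 to compound 4 (0.06 log units; within the scatter) and nothing beyond the scatter is expected in this assay in either direction. For compound 4 the estimated value is 9000 nM with an expected range from 4000 nM to 20000 nM around it.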

Compound 4, half-maximal inhibitory concentration: 16100 nM
The estimate for compound 4 lay 1.8-fold (0.25 log units) below the measured number; low and high end bracket the measured number.
By their numbers in this assay, from the lowest: compounds 2, 3, 4 and 1 (each within the scatter of the next, the first and the last beyond it).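

In this assay, the series now has its first pair differing in one place, with a 1.6-fold higher number from compound 3 to compound 4 (0.19 log units; within the scatter). Chloro in place of methyl at this position, para to a large group, therefore stays within the scatter, and this single pair gives the change no direction. Nothing measured on these compounds offers an explanation for the result.

From the compounds shown here alone, whether an amine or a carboxylic acid in place of the chloro would move the number beyond the scatter remains open. So does whether chloro in place of methyl reads the same with other groups on the shared core.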